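The source may hold more compounds than are shown below. What is called first, only, known or untested is meant among the compounds shown, and "the series" means these compounds.

Compound 1 `O=C(Nc1ccc(F)cc1F)c1cc(F)ccc1O`: 15700 nM
Compound 2 `O=c1oc2ccc(I)cc2c(=O)n1-c1ccc(Cl)cc1F`: 8900 nM
Compound 3 `O=C(Nc1ccc(F)cc1F)c1cc(I)ccc1O`: 13700 nM

All three were tested in an ADME assay on RAW264.7 cells (Mus musculus) for cytotoxicity, read by MTT assay, with a stated time of 24 h; on this read-out lower numbers stand for higher toxicity in this test and higher numbers for lower toxicity in this test. Compound 1 and compound 3 share one core, compound 2 has another; the difference between the two cores is not broken down here. Compound 3 turns into compound 1 by a single change, (fluoro in place of iodo on an aromatic carbon), which gave a 1.1-fold higher number from compound 3 to compound 1 (0.06 log units; within the scatter). Compound 4 `O=c1oc2ccc(F)cc2c(=O)n1-c1ccc(Cl)cc1F` has not been measured; it arises from compound 2 by the same kind of change, (fluoro in place of iodo on an aromatic carbon), though here the place is part of a fused or bridged system of two rings, meta to a fused ring and para to a fused ring, whereas in compound 1 it is meta to a large group and para to a hydroxy group. For compound 4 only a small step is expected, a 1.1-fold higher number from compound 2 to compound 4 (0.03 log units; within the scatter), because the matching step a 1.1-fold higher number from compound 3 to compound 1 (0.06 log units; within the scatter) stayed within the scatter. Compound 4 is therefore estimated at 9500 nM in this assay, most likely between 4500 nM and 20000 nM.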

Compound 4, half-maximal cytotoxic concentration: 7900 nM
Beside the measured number, compound 4's estimate is 1.2-fold (0.08 log units) above it; the range from low to high includes it.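

In this assay, putting fluoro in place of iodo on the core of compound 2 gave a 1.1-fold lower number from compound 2 to compound 4 (0.05 log units; within the scatter). Set beside the same change on the other core, the two steps agree: the same change on two cores in this assay, a 1.1-fold higher number (0.06 log units; within the scatter) from compound 3 to compound 1 and a 1.1-fold lower number (0.05 log units; within the scatter) from compound 2 to compound 4, 1.3-fold (0.11 log units) apart, within the scatter of two such steps. For these two pairs, then, the change carries from one core to the other without a visible difference, but both steps are small, so this does not show how a larger effect would carry, and two pairs make no rule for the series.

The compounds shown compare only iodo and fluoro at this place. They leave open whether a quite different group there, such as an amine or a carboxylic acid, would shift the number in this test on either core.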